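The source may hold more compounds than are shown below. What is called first, only, known or untested is meant among the compounds shown, and "the series" means these compounds.

Measured compounds:
compound 1 `Cc1cc(C)c(S(=O)(=O)N2CCN(c3ccc(C(=O)/C=C/c4ccccc4)cc3)CC2)c(C)c1` gives 55.5%
compound 2 `O=C(/C=C/c1ccccc1)c1ccc(N2CCN(S(=O)(=O)c3ccccc3)CC2)cc1` gives 30%

Both values come from a functional assay on the whole organism (strain Kunming) for inhibition, with Mus musculus as the target, with a stated time of 1 h, at a dose of 40 mg/kg by the oral route; on this read-out higher numbers stand for more inhibition at the one dose given (going by the name of the read-out) and lower numbers for less inhibition. For the measured compounds named here, compound 2 stands lowest of the two numbers, and its only neighbour is compound 1, which sits higher by a margin that exceeds the usual scatter; the one measured step, a number 25.5 percentage points lower from compound 1 to compound 2 (beyond the scatter), came with a phenyl replacing a 2,4,6-trimethylphenyl on the sulfonyl sulfur.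

Compound 3 `COc1ccc(S(=O)(=O)N2CCN(c3ccc(C(=O)/C=C/c4ccccc4)cc3)CC2)cc1OC` has not yet been measured in this assay. It differs from compound 2 in one place: 3,4-dimethoxyphenyl in place of phenyl on a sulfonyl sulfur. Going by the values given here, the single step that bears on this change is a number 25.5 percentage points lower from compound 1 to compound 2 (beyond the scatter), which shows that taking substituents off the phenyl on the sulfonyl sulfur lowered the inhibition in this assay by a modest amount. Putting substituents back onto that phenyl, here as 3,4-dimethoxyphenyl, is therefore expected to move compound 3 upward in this assay, though with a single comparison the size is uncertain. Compound 3 is estimated at 43%, with a range from 25% to 60%. The expected step is a number 13 percentage points higher from compound 2 to compound 3 (beyond the scatter).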

Compound 3, a percentage reported as inhibition, in the whole organism at one dose (the size of the read-out at that dose, not a potency): 55.5%
Estimate against measurement, compound 3: 12.5 percentage points below, within the range that was stated.
By their numbers in this assay, from the lowest: compound 2; then compounds 1 and 3 (each within the scatter of the next).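

In this assay, this position on the sulfonyl sulfur now has a second substituted phenyl to set against the bare phenyl of compound 2, and the change to 3,4-dimethoxyphenyl gives a number 25.5 percentage points higher from compound 2 to compound 3 (beyond the scatter). The exchange of 2,4,6-trimethylphenyl for 3,4-dimethoxyphenyl gives no change at the digits printed from compound 1 to compound 3 (within the scatter), so two phenyl groups with different substituents, one with methyl groups and one with methoxy groups, cannot be told apart here, and among these three compounds only the unsubstituted phenyl stands apart. Nothing measured here explains this difference in inhibition, so the data give no reason for it.

The compounds shown leave open whether a single methoxy group on the phenyl would read the same as the 3,4-dimethoxyphenyl, and how the read-out would respond to a phenyl carrying an amine or a carboxylic acid. They also leave open whether an aromatic ring is needed on the sulfonyl sulfur at all, a question that a methyl group or a longer alkyl chain in that place would address.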